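Benzyl substituent change on a trimethoxyphenyl sulfonamide

The source may report more compounds than this note shows. Statements on the series, on what has been measured and on what is new or still open speak of the compounds shown alone.

Measured so far in a functional assay on MGC-803 cells (Homo sapiens) for inhibition, read by MTT assay, with a stated time of 48 h; a lower number here means a stronger inhibitor, a higher number a weaker inhibitor:
Compound 1 `COc1ccc(CN(c2cc(OC)c(OC)c(OC)c2)S(=O)(=O)c2ccccc2)cc1` gives only a limit, > 50000 nM.
Compound 2 `COc1ccc(CN(c2cc(OC)c(OC)c(OC)c2)S(=O)(=O)c2ccc(OC)c(OC)c2)cc1` gives 8310 nM.
Compound 3 `COc1cc(N(Cc2ccc(Cl)cc2)S(=O)(=O)c2ccc(C)cc2)cc(OC)c1OC` gives 1720 nM.

Among these, compound 3 stands at the lowest of the two actual numbers; compound 2 lies higher by a margin beyond the scatter, and compound 1 contributes only a limit (the limit of > 50000 nM in this assay, at which 1 of the 3 values shown sits). Going by the values given here, the single step between measured compounds, an at least 6.0-fold lower number from compound 1 to compound 2 (0.77 log units; beyond the scatter), concerns the group on the sulfonyl sulfur and is beyond the scatter.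

Compound 4 `COc1cc(N(Cc2cccc(C)c2)S(=O)(=O)c2ccc(C)cc2)cc(OC)c1OC` differs from compound 3 in another place: 3-methylphenyl in place of 4-chlorophenyl on a saturated chain carbon bound to a sulfonamide nitrogen. Among the compounds with values here, the measured step from compound 1 to compound 2 therefore does not bear on this change, and no measured pair varies the benzyl group at all. With the sulfonyl group and the shared core held constant, and with no evidence on the benzyl side in either direction, the expectation is a change no larger than the scatter, perhaps a slightly higher number; the estimated step is a 1.7-fold higher number from compound 3 to compound 4 (0.24 log units; within the scatter). Compound 4 is accordingly expected to give about 3000 nM in this assay, with a plausible range from 900 nM to 10000 nM.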

Compound 4, half-maximal inhibitory concentration: 4340 nM
Compound 4: middle estimate off by 1.4-fold (0.16 log units), on the low side, within the range that was stated.
By their numbers in this assay, from the lowest: compound 3; then compounds 4 and 2 (each within the scatter of the next). At a limit, above all of these: compound 1.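

In this assay, going by these compounds alone, the benzyl side of the sulfonamide nitrogen now has a measured step of its own (a 2.5-fold higher number from compound 3 to compound 4 (0.40 log units; beyond the scatter)), the first evidence that the group at this place affects the read-out, as the earlier step concerned only the group on the sulfonyl sulfur. The 4-chlorophenyl and 3-methylphenyl groups match in heavy-atom count, in their six-membered aromatic ring of carbon only and in having no hydrogen-bond donors or acceptors, so these counts do not separate them, yet the step still lies beyond the scatter. Nothing measured here bears on the reason for this step.

The change from 4-chlorobenzyl to 3-methylbenzyl replaces the substituent and moves it on the ring in a single step, so it remains open which of the two accounts for the higher number. Also open, as far as these compounds go, is how this place would respond to a plain benzyl group, to a benzyl group carrying an amine or a carboxylic acid, or to a longer chain between the ring and the sulfonamide nitrogen.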